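The source may report more compounds than this note shows. Statements on the series, on what has been measured and on what is new or still open speak of the compounds shown alone.

Compound 1 `O=C1c2ccccc2CN1C1CCN(CC(O)COc2cccc(C(F)(F)F)c2)CC1`: 1200 nM
Compound 2 `O=C1CCc2c(cccc2N2CCN(CC(O)COc3ccccc3C(=O)c3ccccc3)CC2)N1`: 21000 nM

In an assay on isolated protein for inhibition of sodium channel protein type 1 subunit alpha (Homo sapiens), read by patch clamp (on this read-out lower numbers stand for stronger inhibition and higher numbers for weaker inhibition), compound 1 gives 1200 nM, while compound 2 gives 21000 nM. Of these two numbers, compound 1 stands at the lower one, and compound 2 sits at a clearly higher value, so compound 1 is the stronger inhibitor of the pair.

Compound 3 `COc1ccc(OCC(O)CN2CCC(N3Cc4ccccc4C3=O)CC2)cc1` has not yet been measured. It differs from compound 1 in a single place: 4-methoxyphenyl in place of 3-(trifluoromethyl)phenyl on an oxygen on a saturated carbon. For the measured compounds named here, no measured pair shows this exchange, and the rest of the structure is kept unchanged, so the step has to be estimated without a direct precedent. The expected step is a 2.5-fold higher number from compound 1 to compound 3 (0.40 log units; beyond the scatter), toward weaker inhibition, modest in size and not far outside the usual scatter of repeated measurements. Compound 3 is therefore estimated at 3000 nM, with a plausible range from 1000 nM to 10000 nM.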

Compound 3, half-maximal inhibitory concentration: 2700 nM
For compound 3 the middle estimate is 1.1-fold (0.05 log units) above the measured one; the measured number falls inside the stated range.
By their numbers in this assay, from the lowest: compound 1; then compound 3; then compound 2.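

In this assay, the exchange of 3-(trifluoromethyl)phenyl for 4-methoxyphenyl on an oxygen on a saturated carbon gives a 2.3-fold higher number from compound 1 to compound 3 (0.35 log units; beyond the scatter) with the rest of the structure unchanged. For the compounds shown here, this is the first direct reading at this position, and it shows that inhibition weakens only modestly, though beyond the usual scatter, when this group is exchanged. No measurement shown links this step to a property of either group. The exchange also alters two things at once, the substituent and its place on the ring, and the compounds shown cannot separate them. As far as these compounds go, how unsubstituted phenyl, or a phenyl ring carrying an amine or a carboxylic acid, would compare in this assay on the core of compound 1 also remains open.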